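Benzyl in Place of Methyl on Selenium

The source may hold more compounds than are shown below. What is called first, only, known or untested is meant among the compounds shown, and "the series" means these compounds.

Measured so far:
Compound 1 `C[Se]/C(=N\C(=O)c1ccco1)NC(=O)c1ccco1`: 8660 nM
Compound 2 `CS/C(=N\C(=O)c1cc2ccccc2s1)NC(=O)c1cc2ccccc2s1`: 53000 nM
Compound 3 `CS/C(=N\C(=O)c1cccs1)NC(=O)c1cccs1`: > 100000 nM

Of the compounds shown here, three have been tested in a functional assay on HepG2 cells (Homo sapiens) for cytotoxicity, read by MTT assay, with a stated time of 72 h; a lower number here means a stronger inhibitor of growth, a higher number a weaker inhibitor of growth. Compound 1, built around a selenium-bearing core, gives 8660 nM in this assay. Compound 2 gives 53000 nM, a higher number, and the gap between compound 1 and compound 2 lies beyond the usual scatter. Compound 3 gives > 100000 nM, which is a limit of the assay and not a number (the limit of > 100000 nM in this assay, at which 1 of the 3 values shown sits). Among the two actual numbers, compound 1 therefore stands lowest, meaning the strongest growth inhibition seen so far.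

Compound 4 `O=C(/N=C(/NC(=O)c1ccco1)[Se]Cc1ccccc1)c1ccco1` has not yet been measured. It differs from compound 1 in one place: phenyl in place of hydrogen on a saturated chain carbon bound to a selenium atom. Put another way, the methyl on selenium becomes a benzyl. Among the measured compounds shown here, no measured pair shows a change of this kind, so there is nothing to lean on for its size or direction. The expectation is that the change stays modest, close to the scatter, with the step from compound 1 to compound 4 estimated as a 1.4-fold lower number from compound 1 to compound 4 (0.16 log units; within the scatter). Compound 4 is thus expected to give about 6000 nM in this assay, likely between 1500 nM and 25000 nM.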

Compound 4, concentration for total growth inhibition: 39500 nM
For compound 4 the middle estimate is 6.6-fold (0.82 log units) below the measured one; the whole stated range lies below it.
By their numbers in this assay, from the lowest: compound 1; then compounds 4 and 2 (each within the scatter of the next). At a limit, above all of these: compound 3.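

The group on selenium turns out to matter: in this assay, replacing methyl with benzyl gives a 4.6-fold higher number from compound 1 to compound 4 (0.66 log units; beyond the scatter). Adding a phenyl on the saturated chain carbon bound to the selenium atom therefore weakens growth inhibition here rather than leaving it unchanged, so a larger group at this position is not freely tolerated. This is the only change in a single place among the compounds shown, so it describes this one swap on the core of compound 1 and sets no general rule. The measurements shown do not say why the phenyl has this effect.

Still open, going by these compounds, is how an ethyl or a longer chain on selenium would read, which would help separate the contribution of chain length from that of the phenyl ring. Also open is what a benzyl carrying an amine or a carboxylic acid on its ring would do, and whether sulfur in place of selenium matters at all; the sulfur compounds shown differ from compound 1 in more than one place.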